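Moving the nitrile on the cyanophenyl group of compound 1

The source may hold more compounds than are shown below. What is called first, only, known or untested is meant among the compounds shown, and "the series" means these compounds.

In a functional assay on A549 cells (Homo sapiens) for antiproliferative activity, read by MTT assay, with a stated time of 72 h (on this read-out lower numbers stand for stronger inhibition and higher numbers for weaker inhibition), compound 1 `COc1cc2c(Nc3ccc(C#N)cc3)ncnc2cc1OCCCN1CCCC1` gives 21800 nM. Compound 3 `COc1cc2c(Nc3ccc(C#N)cc3)ncnc2cc1OCCCN1CCN(c2ccncc2)CC1` gives 25500 nM, within the scatter of compound 1, and compound 2 `COc1cc2c(Nc3ccc(C#N)cc3)ncnc2cc1OCCCN1CCN(C)CC1` gives 48800 nM. Compound 1 thus stands level with compound 3 and has the lower number only against compound 2.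

Compound 4 `COc1cc2c(Nc3cccc(C#N)c3)ncnc2cc1OCCCN1CCCC1` has the same atoms as compound 1, joined differently: 3-cyanophenyl in place of 4-cyanophenyl on a nitrogen on an aromatic ring. Among the compounds with values here, no measured step touches this group. All three exchange the ring amine on the chain, giving a 2.2-fold higher number from compound 1 to compound 2 (0.35 log units; beyond the scatter), a 1.2-fold higher number from compound 1 to compound 3 (0.07 log units; within the scatter) and a 1.9-fold lower number from compound 2 to compound 3 (0.28 log units; within the scatter). These small steps show how narrow the range is so far, but they give no direction for a change on the cyanophenyl group. No step beyond the scatter is therefore expected in this assay. The estimated step is a 1.1-fold lower number from compound 1 to compound 4 (0.04 log units; within the scatter). Compound 4 is expected at 20000 nM, with an estimated range from 7000 nM to 50000 nM.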

Compound 4, half-maximal inhibitory concentration: 39900 nM
Compound 4: middle estimate off by 2.0-fold (0.30 log units), on the low side; low and high end bracket the measured number.
By their numbers in this assay, from the lowest: compounds 1, 3, 4 and 2 (each within the scatter of the next, the first and the last beyond it).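

Exchanging 4-cyanophenyl for 3-cyanophenyl on a nitrogen on an aromatic ring is the first change at this group among the compounds shown, and in this assay it gives a 1.8-fold higher number from compound 1 to compound 4 (0.26 log units; within the scatter). This shift of the nitrile therefore leaves compound 4 level with compound 1 within the scatter, so this one change gives no clear direction for the cyanophenyl group. No evidence bears on what lies behind this result.

The compounds shown leave open whether a chlorine or a carboxylic acid in place of the nitrile would stay within this narrow range. They also leave open whether 3-cyanophenyl would give a similar step alongside the 4-methylpiperazin-1-yl of compound 2 or the 4-(pyridin-4-yl)piperazin-1-yl of compound 3.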